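From compound 3 to compound 4: a longer amine chain

A few compounds are considered here, and "the series" means these few. Any claim that something is new, unique, unknown or untested is made for them only; others in the source may bear on it.

In a functional assay on K562 cells (Homo sapiens) for antiproliferative activity, read by MTT assay, with a stated time of 48 h (on this read-out higher numbers stand for weaker inhibition and lower numbers for stronger inhibition), compound 1 `CCN(CC)CCn1c(N)c(-c2nc3ccccc3[nH]2)c2nc(C#N)c(C#N)nc21` gives 2490 nM and compound 2 `CN(C)CCn1c(N)c(-c2nc3ccccc3s2)c2nc(C#N)c(C#N)nc21` gives 8000 nM. Compound 3 `CCN(CC)CCn1c(N)c(-c2nc3ccccc3n2C)c2nc(C#N)c(C#N)nc21` gives > 50000 nM, which is a limit and not a number. Compound 3 therefore stands at the limit of > 50000 nM in this assay, at which 1 of the 3 values shown sits, with no exact position in the series.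

Among the compounds with values here, the one measured step is an at least 20-fold higher number from compound 1 to compound 3 (1.30 log units; beyond the scatter), with methyl in place of hydrogen on an aromatic nitrogen. Compound 4 `CCN(CC)CCCCn1c(N)c(-c2nc3ccccc3n2C)c2nc(C#N)c(C#N)nc21` keeps that methyl and differs from compound 3 only in the chain: 2-(diethylamino)ethyl in place of diethylamino on a saturated chain carbon, two bonds along the chain from an aromatic nitrogen. In words, this is 2-(diethylamino)ethyl in place of diethylamino on a saturated chain carbon, two bonds along the chain from an aromatic nitrogen, so that a 2-(diethylamino)ethyl chain becomes 4-(diethylamino)butyl.

Within the data shown here, no measured step changes this chain, so the evidence on the change in this assay is thin. The large step to compound 3 does not reverse here, since the methyl stays, and compound 4 is expected to remain weak, possibly again at the limit. Any readable number would lie modestly toward stronger inhibition. The expected step is an at least 1.6-fold lower number from compound 3 to compound 4 (0.22 log units; that floor lies within the scatter). Compound 4 is estimated at 30000 nM, with an expected range of 8000 nM to 70000 nM.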

Compound 4, half-maximal inhibitory concentration: 1010 nM
Beside the measured number, compound 4's estimate is 30-fold (1.47 log units) above it; measured number below the stated range.
By their numbers in this assay, from the lowest: compound 4; then compound 1; then compound 2. At a limit, above all of these: compound 3.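

In this assay, within the data shown here, the step from the 2-(diethylamino)ethyl chain to the 4-(diethylamino)butyl chain gives an at least 49-fold lower number from compound 3 to compound 4 (1.69 log units; beyond the scatter) and is the first measured change at this position, so the amine chain can carry a large difference in this methylated pair. The size of that step is a floor and not an exact figure, because compound 3 stands at a limit: the limit of > 50000 nM in this assay, at which 1 of the 4 values shown sits. The methyl on the aromatic nitrogen, linked on the shorter chain to (an at least 20-fold higher number from compound 1 to compound 3 (1.30 log units; beyond the scatter)), also does not by itself leave a compound without a readable number, since compound 4 carries the same methyl and gives 1010 nM in this assay.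

The compounds shown leave open whether the 4-(diethylamino)butyl chain would bring a comparable step with hydrogen in place of that methyl. They also leave open how a 3-(diethylamino)propyl chain or a still longer amine chain would read, and so whether the difference follows chain length across a series or belongs to this single pair.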